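The source may hold more compounds than are shown below. What is called first, only, known or untested is meant among the compounds shown, and "the series" means these compounds.

Results in a functional assay on the whole organism for inhibition, with Lemna aequinoctialis as the target, with a stated time of 7 days, tested at 5 ug/mL; a higher number here means more inhibition of growth at the concentration tested, a lower number less inhibition of growth:
- compound 1 `O=C1Nc2ccc(F)cc2/C1=N/NC(=S)Nc1cccc(F)c1`: 15%
- compound 2 `O=C1Nc2ccc(F)cc2/C1=N/NC(=S)Nc1ccc(F)cc1`: 10%
- compound 3 `O=C1Nc2ccc(F)cc2/C1=N/NC(=S)Nc1ccc(F)cc1F`: 10%

Compound 3 sits level with compound 2 and within the usual scatter of compound 1, so these numbers do not separate the three. Compound 4 `O=C1Nc2ccc(F)cc2/C1=N/NC(=S)Nc1cc(F)cc(F)c1` keeps the shared core and has the same atoms as compound 3, joined differently: 3,5-difluorophenyl in place of 2,4-difluorophenyl on an amide-type nitrogen.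

Three measured steps changed the same aryl group: a number 5 percentage points lower from compound 1 to compound 2 (within the scatter), a number 5 percentage points lower from compound 1 to compound 3 (within the scatter) and no change at the digits printed from compound 2 to compound 3 (within the scatter). None of them left the scatter, so no step beyond the scatter is expected in this assay.

The expected step is a number 2 percentage points higher from compound 3 to compound 4 (within the scatter).

Compound 4 is estimated to give 12%, within an expected range of 3% to 25%.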

Compound 4, percent growth inhibition at one concentration: 0%
Compound 4: the middle estimate sits 12 percentage points above what was measured; the whole stated range lies above it.
By their numbers in this assay, from the lowest: compounds 4, 2, 3 and 1 (each within the scatter of the next, the first and the last beyond it).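

On the amide-type nitrogen in this assay, 3,5-difluorophenyl gives a number 10 percentage points lower from compound 3 to compound 4 (within the scatter) and a number 10 percentage points lower from compound 2 to compound 4 (within the scatter), so neither swap separates these compounds. Within the data shown here, the swap from 3-fluorophenyl is the first step here to pass the scatter, though only modestly, with a number 15 percentage points lower from compound 1 to compound 4 (beyond the scatter). Placing a fluoro in place of hydrogen on this aryl group therefore has no single outcome, and its result differs with the aryl group that receives it: the same change on two cores in this assay, no change at the digits printed (within the scatter) from compound 2 to compound 3 and a number 15 percentage points lower (beyond the scatter) from compound 1 to compound 4, 15 percentage points apart, beyond the scatter of two such steps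

Every group shown at this position is a fluorinated phenyl. As far as these compounds go, whether a phenyl carrying a carboxylic acid or an amine, or a longer alkyl chain, would move the number beyond the scatter remains open.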